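The source may report more compounds than this note shows. Statements on the series, on what has been measured and on what is new or still open speak of the compounds shown alone.

Of the compounds shown here, two have so far been measured in an in vitro functional assay on Ltk cells for inhibition of metabotropic glutamate receptor 5 (Homo sapiens), read by calcium flux; a higher number here means a weaker inhibitor, a lower number a stronger inhibitor. Compound 1 `CC(C)(C)OC(=O)N1CC=C(C#Cc2ccccn2)CC1` gives 2.6 nM in this assay. Among the measured compounds shown here, compound 2 `O=S(=O)(Cc1ccccc1)N1CC=C(C#Cc2ccccn2)CC1` gives 58 nM in this assay, the highest of the two numbers; its only neighbour is compound 1, and the gap between them lies well beyond the scatter of the method. Compound 3 `Cc1cccc(S(=O)(=O)N2CC=C(C#Cc3ccccn3)CC2)c1` has not yet been measured. It differs from compound 2 in one place: 3-methylphenyl in place of benzyl on a sulfonyl sulfur. The two compounds hold the same atoms, joined differently. For the measured compounds named here, no step between measured compounds of this kind is available, so the expectation rests on the values of compound 1 and compound 2 alone. A modest step toward a lower number is expected, estimated at a 1.7-fold lower number from compound 2 to compound 3 (0.22 log units; within the scatter), and it may not exceed the scatter. Compound 3 is estimated at 35 nM, within a range from 10 nM to 150 nM.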

Compound 3, half-maximal inhibitory concentration: 8.2 nM
Compound 3: the middle estimate sits 4.3-fold (0.63 log units) above what was measured; measured number outside the range, below it.
By their numbers in this assay, from the lowest: compound 1; then compound 3; then compound 2.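

In this assay, the exchange of benzyl for 3-methylphenyl on a sulfonyl sulfur gives a 7.1-fold lower number from compound 2 to compound 3 (0.85 log units; beyond the scatter). This shows that the group at this place can shift the number well beyond the scatter, even when the group that leaves and the group that enters hold the same count of heavy atoms, one six-membered aromatic ring of carbon only and no hydrogen-bond donors or acceptors. Nothing available explains the size or direction of this step.

The compounds shown leave open whether the methyl group contributes to this step at all, as an unsubstituted phenyl would show. They also leave open how a methoxy group or a chlorine atom on the aromatic ring, or a small alkyl group such as ethyl on the sulfonyl sulfur, would compare with 3-methylphenyl.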